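Thiophene to Thiazole on the Sulfonyl Group

The source may report more compounds than this note shows. Statements on the series, on what has been measured and on what is new or still open speak of the compounds shown alone.

Measured in a functional assay on HepG2 cells for inhibition of squalene monooxygenase (Homo sapiens); a lower number here means a stronger inhibitor, a higher number a weaker inhibitor:
compound 1 `CCN(C/C=C/C#CC(C)(C)C)Cc1cccc(OCCN(C)S(=O)(=O)c2cccs2)c1` gives 60 nM
compound 2 `CCN(C/C=C/C#CC(C)(C)C)Cc1cccc(OCCN(C)S(=O)(=O)c2ccc(Br)cc2)c1` gives 330 nM

Among the measured compounds shown here, compound 1 holds the lower of the two numbers; the only measured step is a 5.5-fold higher number from compound 1 to compound 2 (0.74 log units; beyond the scatter). Compound 3 `CCN(C/C=C/C#CC(C)(C)C)Cc1cccc(OCCN(C)S(=O)(=O)c2nccs2)c1` differs from compound 1 by 1,3-thiazol-2-yl in place of thiophen-2-yl on a sulfonyl sulfur. For the measured compounds named here, only that step bears on the change, since it also replaced the group on the sulfonyl sulfur, and it was modest. A smaller change of the same kind is expected to cost little, so compound 3 is estimated at 100 nM in this assay, between 40 nM and 300 nM. That estimate means a step of a 1.7-fold higher number from compound 1 to compound 3 (0.22 log units; within the scatter).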

Compound 3, half-maximal inhibitory concentration: 170 nM
Compound 3: middle estimate off by 1.7-fold (0.23 log units), on the low side; low and high end bracket the measured number.
By their numbers in this assay, from the lowest: compound 1; then compounds 3 and 2 (each within the scatter of the next).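

In this assay, the group on the sulfonyl sulfur proves sensitive even to an exchange that keeps five heavy atoms and a five-membered aromatic ring, with a nitrogen entering for a carbon: the result is a 2.8-fold higher number from compound 1 to compound 3 (0.45 log units; beyond the scatter). The 1,3-thiazol-2-yl group and the 4-bromophenyl group are not separated, at a 1.9-fold lower number from compound 2 to compound 3 (0.29 log units; within the scatter). Nothing in the data given accounts for either step.

The compounds shown leave open whether a furan-2-yl or chlorothiophene ring on the sulfonyl sulfur would match thiophen-2-yl. They also leave open whether an unsubstituted phenyl would differ from 4-bromophenyl.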